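Carbamate to nitrobenzoate ester on the shared core

This account rests on a few compounds, and the source may have more. Where it says the series, first, only, none or still open, it means among the compounds named here.

Measured so far:
compound 1 `CC1=CC[C@H]2[C@@H]1CC=C(C)[C@@H](CC[C@H]1[C@]3(C)CC[C@H](OC(=O)c4ccc(Cl)cc4)C(C)(C)O[C@H]3CC[C@@]1(C)O)C2(C)C`: 12700 nM
compound 2 `CC1=CC[C@H]2[C@H](CC[C@]2(C)O)C(C)(C)[C@@H]1CC[C@H]1[C@]2(C)CC[C@H](OC(=O)NCc3ccccc3)C(C)(C)O[C@H]2CC[C@@]1(C)O`: 40300 nM

Both compounds were run in a functional assay on MDA-MB-231 cells (Homo sapiens) for antiproliferative activity, read by MTT assay, with a stated time of 72 h; on this read-out higher numbers stand for weaker inhibition and lower numbers for stronger inhibition. Compound 1 gives 12700 nM. Compound 2 gives 40300 nM, the higher of the two numbers; the gap to compound 1 lies beyond the scatter. For the measured compounds named here, the two compounds differ in more than one place, so the gap cannot be assigned to any single change, and no single-point step between them is available.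

Compound 3 `CC1=CC[C@H]2[C@H](CC[C@]2(C)O)C(C)(C)[C@@H]1CC[C@H]1[C@]2(C)CC[C@H](OC(=O)c3ccccc3[N+](=O)[O-])C(C)(C)O[C@H]2CC[C@@]1(C)O` keeps the core of compound 2 and differs in one place: 2-nitrophenyl in place of benzylamino on a carbonyl carbon. Going by the values given here, no measured pair isolates this kind of change, so the expectation rests on the weak position of compound 2 at 40300 nM and on compound 1, an ester rather than a carbamate, sitting at the lower number 12700 nM on a different core. The step of a 2.0-fold lower number from compound 2 to compound 3 (0.30 log units; within the scatter) is expected to be small, toward stronger inhibition, and near the edge of the scatter. Compound 3 is estimated at 20000 nM in this assay, with a range from 6000 nM to 60000 nM.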

Compound 3, half-maximal inhibitory concentration: 38700 nM
Compound 3: middle estimate off by 1.9-fold (0.29 log units), on the low side; low and high end bracket the measured number.
By their numbers in this assay, from the lowest: compound 1; then compounds 3 and 2 (each within the scatter of the next).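

In this assay the step with 2-nitrophenyl in place of benzylamino on a carbonyl carbon is a 1.0-fold lower number from compound 2 to compound 3 (0.02 log units; within the scatter) and, on the shared core, this first single-place pair therefore does not separate the carbamate of compound 2 from the nitrobenzoate ester of compound 3. The exchange is not a small one on paper: the hydrogen-bond donor of benzylamino leaves, hydrogen-bond acceptors enter with 2-nitrophenyl, and the aromatic ring of carbon only is kept, yet the read-out for this pair does not respond beyond the scatter. No independent measurement is available to account for this outcome.

One pair on one core cannot show whether this position tolerates change in general or whether both of these groups simply sit in the same weak range of the read-out. Still open, going by these compounds, is how the position would answer to a group of a different kind on the same carbonyl carbon, such as a primary amine, a carboxylic acid or a longer alkyl chain, and whether any of these would move the number beyond the scatter in either direction.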